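Capping the amine of compound 1 with a methylurea

The source may report more compounds than this note shows. Statements on the series, on what has been measured and on what is new or still open speak of the compounds shown alone.

Compound 1, `NC[C@@H]1CCCc2cc(S(=O)(=O)c3cccc(F)c3)ccc21`, is the parent of this small set. In an assay on isolated protein for displacement of a labelled ligand from 5-hydroxytryptamine receptor 6 (Homo sapiens) (a higher number here means a weaker inhibitor, a lower number a stronger inhibitor), compound 1 gives 0.0794 nM, the lowest number among the three measured compounds. Its two measured neighbours both carry a substituent on the amine nitrogen: compound 2, `O=C(NC[C@@H]1CCCc2cc(S(=O)(=O)c3cccc(F)c3)ccc21)[C@H]1CCCN1`, gives 0.631 nM, and compound 3, `CN(C)C(=O)NC[C@@H]1CCCc2cc(S(=O)(=O)c3cccc(F)c3)ccc21`, gives 2.51 nM. Both steps away from compound 1 weaken binding, a 7.9-fold higher number from compound 1 to compound 2 (0.90 log units; beyond the scatter) and a 32-fold higher number from compound 1 to compound 3 (1.50 log units; beyond the scatter), with the urea of compound 3 costing more than the amide of compound 2, as a 4.0-fold higher number from compound 2 to compound 3 (0.60 log units; beyond the scatter) shows.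

Compound 4, `CN(C[C@@H]1CCCc2cc(S(=O)(=O)c3cccc(F)c3)ccc21)C(N)=O`, is not yet measured. It differs from compound 1 by carbamoyl(methyl)amino in place of amino on a saturated chain carbon bound to a saturated ring carbon. Going by the values given here, the change again replaces a hydrogen on the amine nitrogen, this time with a carbamoyl together with a methyl, so the urea-type loss seen for compound 3 is the closest precedent. Compound 4 is therefore expected to bind more weakly than compound 1, with a step of about a 25-fold higher number from compound 1 to compound 4 (1.40 log units; beyond the scatter). The estimated value for compound 4 in this assay is 2 nM, with a likely range from 0.5 nM to 8 nM.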

Compound 4, inhibition constant: 39.8 nM
The estimate for compound 4 lay 20-fold (1.30 log units) below the measured number, outside the stated range (above it).
By their numbers in this assay, from the lowest: compound 1; then compound 2; then compound 3; then compound 4.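

In this assay the arrangement of a urea on the amine nitrogen matters, not only its presence: the two ureas stand far apart (a 16-fold higher number from compound 3 to compound 4 (1.20 log units; beyond the scatter)), and the weaker of them alone carries a methyl on that nitrogen in place of the hydrogen the other keeps. This change also gives the largest loss from the parent in the set (a 500-fold higher number from compound 1 to compound 4 (2.70 log units; beyond the scatter)), and it falls well behind the amide too (a 63-fold higher number from compound 2 to compound 4 (1.80 log units; beyond the scatter)). Nothing at hand gives a reason for these losses.

The compounds shown leave open whether a methyl alone on the amine nitrogen, with no carbamoyl, would give a loss of this size. They also leave open how an acetyl group or a longer alkyl chain on that nitrogen would compare with the parent and with the ureas.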